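The source may hold more compounds than are shown below. What is called first, only, known or untested is meant among the compounds shown, and "the series" means these compounds.

Measured in an assay on isolated protein for inhibition of transient receptor potential cation channel subfamily V member 1 (Homo sapiens), read by calcium flux; on this read-out higher numbers stand for weaker inhibition and lower numbers for stronger inhibition:
Compound 1 `O=C(Nc1cccc2[nH]ncc12)NC1CCc2ccccc21` gives 151 nM.
Compound 2 `Cc1ccc2c(c1)CCC2NC(=O)Nc1cccc2[nH]ncc12` gives 11 nM.
Compound 3 `COc1ccc2c(c1)CCC2NC(=O)Nc1cccc2[nH]ncc12` gives 40 nM.

Compound 3 stands second highest of the three numbers; the nearer step is a 3.6-fold higher number from compound 2 to compound 3 (0.56 log units; beyond the scatter), the further one a 3.8-fold lower number from compound 1 to compound 3 (0.58 log units; beyond the scatter). Compound 4 `O=C(Nc1cccc2[nH]ncc12)NC1CCc2cc(Cl)ccc21` differs from compound 3 by chloro in place of methoxy on an aromatic carbon. Among the measured compounds shown here, no measured step involves chloro, so the bearing steps are the substitutions at the same aromatic carbon: a 14-fold lower number from compound 1 to compound 2 (1.14 log units; beyond the scatter), a 3.8-fold lower number from compound 1 to compound 3 (0.58 log units; beyond the scatter) and a 3.6-fold higher number from compound 2 to compound 3 (0.56 log units; beyond the scatter). Both groups that enter there lower the number against hydrogen, and methyl does so more than methoxy, so for compound 4 a modest step downward is expected, a 2.2-fold lower number from compound 3 to compound 4 (0.35 log units; beyond the scatter). Compound 4 is estimated at 18 nM, with a range of 6 nM to 55 nM.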

Compound 4, half-maximal inhibitory concentration: 10 nM
Estimate against measurement, compound 4: 1.8-fold (0.26 log units) above; measured number inside the range.
By their numbers in this assay, from the lowest: compounds 4 and 2 (each within the scatter of the next); then compound 3; then compound 1.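

In this assay chloro at this aromatic carbon gives a 15-fold lower number from compound 1 to compound 4 (1.18 log units; beyond the scatter) against hydrogen and a 4.0-fold lower number from compound 3 to compound 4 (0.60 log units; beyond the scatter) against methoxy, so a third group lowers the number against hydrogen at this position. The step of a 1.1-fold lower number from compound 2 to compound 4 (0.04 log units; within the scatter) leaves chloro and methyl not separable here, with methoxy standing apart from both. Nothing measured here accounts for the match between chloro and methyl or for the gap to methoxy.

Open, as far as these compounds go, is how fluoro, trifluoromethyl or an amine would behave at this carbon. Also open, from the compounds shown here alone, is whether chloro or methyl would give similar numbers on the other aromatic carbons of this ring.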